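The source may hold more compounds than are shown below. What is called first, only, known or untested is meant among the compounds shown, and "the series" means these compounds.

Compound 1 `O=C1Nc2c(ccc(F)c2F)C1(c1ccccc1)c1ccc(O)cc1` gives 7.1 nM in a functional assay on MCF7 cells (Homo sapiens) for cytotoxicity, read by WST assay, with a stated time of 72 h; a higher number here means a weaker inhibitor, a lower number a stronger inhibitor.
Compound 2 `O=C1Nc2c(ccc(F)c2F)C1(c1ccc(O)cc1)c1ccc(F)cc1` gives 2.6 nM in this assay.
Compound 3 `O=C1Nc2c(ccc(F)c2F)C1(c1ccc(O)cc1)C1CCCC1` gives 12 nM in this assay.

Among these three, compound 2 holds the lowest number. Its nearest neighbour is compound 1, with a step of a 2.7-fold lower number from compound 1 to compound 2 (0.44 log units; beyond the scatter), and the furthest is compound 3, reached by a 4.6-fold higher number from compound 2 to compound 3 (0.66 log units; beyond the scatter); both steps lie beyond the scatter.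

The next compound, compound 4 `O=C1Nc2c(ccc(F)c2F)C1(CC1CCCCC1)c1ccc(O)cc1`, differs from compound 2 in one place: cyclohexylmethyl in place of 4-fluorophenyl on a saturated ring carbon.

Within the data shown here, two measured steps bear on this change. Among the measured compounds shown here, the closest is the one from compound 2 to compound 3, where a cyclopentyl replaced the 4-fluorophenyl on the same saturated ring carbon and the number rose by a 4.6-fold higher number from compound 2 to compound 3 (0.66 log units; beyond the scatter). The step from compound 1 to compound 3, cyclopentyl in place of phenyl, was a 1.7-fold higher number from compound 1 to compound 3 (0.23 log units; within the scatter), within the scatter. Compound 4 likewise exchanges the 4-fluorophenyl for a saturated carbon group, here a cyclohexylmethyl, so a rise in the number of modest size, roughly like the step to compound 3, is expected in this assay.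

For compound 4 the expected step from compound 2 is a 5.4-fold higher number from compound 2 to compound 4 (0.73 log units; beyond the scatter). The estimate for compound 4 in this assay is 14 nM, with a range from 5 nM to 45 nM.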

Compound 4, half-maximal inhibitory concentration: 102 nM
Estimate against measurement, compound 4: 7.3-fold (0.86 log units) below; the measured number lies above the stated range.
By their numbers in this assay, from the lowest: compound 2; then compounds 1 and 3 (each within the scatter of the next); then compound 4.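

The earlier steps shown here had suggested that a saturated carbon group on this saturated ring carbon costs little, but in this assay the two saturated groups are not interchangeable, with an 8.5-fold higher number from compound 3 to compound 4 (0.93 log units; beyond the scatter). Replacing an aromatic ring at this position therefore has no single cost: cyclopentyl for phenyl stays within the scatter, with a 1.7-fold higher number from compound 1 to compound 3 (0.23 log units; within the scatter), whereas cyclohexylmethyl gives large rises, with a 14-fold higher number from compound 1 to compound 4 (1.16 log units; beyond the scatter) and a 39-fold higher number from compound 2 to compound 4 (1.59 log units; beyond the scatter). The size of the change depends on which saturated group enters, and no measurement in hand explains the difference.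

Cyclohexylmethyl differs from cyclopentyl in both ring size and the methylene link to the core, and the compounds shown do not separate these two changes. As far as these compounds go, a cyclohexyl group attached directly to this carbon would test the ring alone, a benzyl group would test the link with an aromatic ring, and the effect of an amine on either group remains open.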